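This account rests on a few compounds, and the source may have more. Where it says the series, first, only, none or still open, it means among the compounds named here.

Series notes. Compound 1 `CN(CCCCN(C)C(=O)CCCNc1ncnc2c1ncn2[C@@H]1O[C@H](COP(=O)(O)OP(=O)(O)OP(=O)(O)O)[C@@H](O)[C@H]1O)C(=O)CCCNC(=O)CI` is the larger member of the measured pair; in an assay on isolated protein for inhibition of hexokinase-3 (Rattus norvegicus), with a stated time of 6 h, tested at 10 mM (on this read-out lower numbers stand for less inhibition and higher numbers for more inhibition at the one concentration tested (going by the name of the read-out)), compound 1 gives 0%. Compound 2 `O=C(CI)NCCCNc1ncnc2c1ncn2[C@@H]1O[C@H](COP(=O)(O)OP(=O)(O)OP(=O)(O)O)[C@@H](O)[C@H]1O` is the smaller measured member; in this assay compound 2 gives 0%. On these numbers compound 2 stands level with compound 1 at the digits shown, and compound 1 is its nearest neighbour, with no change beyond the scatter between them; neither compound shows inhibition at the one concentration tested. Compound 3 `O=C(CI)NCCNc1ncnc2c1ncn2[C@@H]1O[C@H](COP(=O)(O)OP(=O)(O)OP(=O)(O)O)[C@@H](O)[C@H]1O` is the next member and remains to be measured in this assay. Its structure differs from compound 2 as follows: ((iodomethyl)carbonyl)amino in place of (((iodomethyl)carbonyl)amino)methyl on a saturated chain carbon, two bonds along the chain from a nitrogen on an aromatic ring. For the measured compounds named here, no step between measured compounds exists to lean on; the only measured pair shows two values at the floor of the read-out. Because compound 2 gives 0%, the expected step is no change at the digits printed from compound 2 to compound 3 (within the scatter), none beyond the scatter, and no direction is favoured. Compound 3 is accordingly estimated at 0%, with an expected range from 0% to 10%.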

Compound 3, a percentage reported as inhibition, at one concentration (the size of the read-out at that concentration, not a potency): 0%
For compound 3 middle estimate and measured number coincide at the digits printed; low and high end bracket the measured number.
By their numbers in this assay, from the lowest: compounds 1, 2 and 3 (each within the scatter of the next).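

In this assay, the first step read at this position, ((iodomethyl)carbonyl)amino in place of (((iodomethyl)carbonyl)amino)methyl on a saturated chain carbon, two bonds along the chain from a nitrogen on an aromatic ring, gives no change at the digits printed from compound 2 to compound 3 (within the scatter). The change removes one carbon from the chain and leaves the counted donors, acceptors and net charge as they were, and at the floor of the read-out it produces no visible effect; a floor reading on both sides cannot show whether this chain length matters to inhibition, as any loss would be hidden. No independent measurement bears on this result.

The compounds shown leave open whether any change at this position can lift the read-out off the floor, for example an amine or a carboxylic acid in place of ((iodomethyl)carbonyl)amino, or a longer chain carrying the same end group. With no reading above the floor in this part of the series, the effect of chain length on inhibition remains undefined.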